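This account rests on a few compounds, and the source may have more. Where it says the series, first, only, none or still open, it means among the compounds named here.

Compound 3 `C[C@@H](NC(=O)Nc1ccccc1C(F)(F)F)c1ccccc1` gives 95% in an ADME assay on the whole organism with Oryza sativa as the target, tested at 1 uM (on this read-out higher numbers stand for a weaker effect at the one concentration tested and lower numbers for a stronger effect), where it stands level with compound 2 `C[C@@H](NC(=O)Nc1ccccc1C(C)(C)C)c1ccccc1` at 95%, the two together being the lowest of three numbers; compound 1 `CC(C)c1ccccc1NC(=O)N[C@H](C)c1ccccc1` gives 101%, and the step of a number 6 percentage points lower from compound 1 to compound 3 (within the scatter). Compound 4 `C[C@@H](NC(=O)Nc1ccccc1Cl)c1ccccc1` carries chloro in place of trifluoromethyl on an aromatic carbon. Among the measured compounds shown here, two measured steps bear on this exchange at the same aromatic carbon: no change at the digits printed from compound 2 to compound 3 (within the scatter) and a number 6 percentage points lower from compound 1 to compound 3 (within the scatter), while a number 6 percentage points lower from compound 1 to compound 2 (within the scatter). Since every swap at that position has so far stayed within the scatter, the author expects no step beyond the scatter from compound 3 to compound 4, a number 2 percentage points higher from compound 3 to compound 4 (within the scatter). Compound 4 is therefore estimated at 97% in this assay, with a range from 85% to 105%.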

Compound 4, a percentage reported as activity, at one concentration (the size of the read-out at that concentration, not a potency): 103%
Beside the measured number, compound 4's estimate is 6 percentage points below it; measured number inside the range.
By their numbers in this assay, from the lowest: compounds 2, 3, 1 and 4 (each within the scatter of the next).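

In this assay, chloro, with 1 heavy atom against the 4 of trifluoromethyl, keeps every comparison at this aromatic carbon within the scatter: a number 8 percentage points higher from compound 3 to compound 4 (within the scatter), a number 8 percentage points higher from compound 2 to compound 4 (within the scatter) and a number 2 percentage points higher from compound 1 to compound 4 (within the scatter). Across the four compounds, a single-atom group therefore cannot be told apart from the three carbon-based groups at this position. No evidence is available to explain this result. Going by these compounds, whether an amine or a carboxylic acid at this aromatic carbon would give a step beyond the scatter remains open, as does the effect of changes elsewhere on the shared core.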